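This account rests on a few compounds, and the source may have more. Where it says the series, first, only, none or still open, it means among the compounds named here.

Compound 3 `C#Cc1cn([C@@H]2O[C@H](CO)[C@@H](O)[C@H]2O)c2ncnc(OC)c12` is one of three nucleosides that have been run in an ADME assay on MRC5 cells (Homo sapiens), read by MTT assay, with a stated time of 72 h; a lower number here means a stronger inhibitor, a higher number a weaker inhibitor. In this assay compound 3 stops at > 100000 nM, which is a limit of the assay and not a number. Compound 1 `COc1ncnc2c1c(-c1ccsc1)cn2[C@@H]1O[C@H](CO)[C@@H](O)[C@H]1O` gives 75300 nM in this assay. Compound 2 `CNc1ncnc2c1c(I)cn2[C@@H]1O[C@H](CO)[C@@H](O)[C@H]1O` likewise stops at > 100000 nM in this assay, again a limit. Going by the values given here, the only step that reaches compound 3, an at least 1.3-fold higher number from compound 1 to compound 3 (0.12 log units; that floor lies within the scatter), cannot be sized closely because of the limit of > 100000 nM in this assay, at which 2 of the 3 values shown sit. Compound 4 `COc1ncnc2c1c(I)cn2[C@@H]1O[C@H](CO)[C@@H](O)[C@H]1O` differs from compound 3 by iodo in place of ethynyl on an aromatic carbon. Among the compounds with values here, no measured step covers this change. Compound 2, which also bears iodo, reaches only a limit in this assay. Compound 3 reaches only a limit as well. No shift beyond the scatter is therefore anticipated in this assay. Compound 4 is expected to give about 150000 nM, somewhere from 70000 nM to 400000 nM, which would amount to an estimated step that the limit leaves unreadable from compound 3 to compound 4.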

Compound 4, half-maximal inhibitory concentration: 63000 nM
The estimate for compound 4 lay 2.4-fold (0.38 log units) above the measured number, and the stated range ends above it.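

In this assay compound 4 gives a number with iodo at this position, an aromatic carbon of the five-membered aromatic ring, so this methoxy series now has a second readable value alongside the thiophen-3-yl of compound 1. Iodo in place of thiophen-3-yl makes no difference that can be told from the scatter, with a 1.2-fold lower number from compound 1 to compound 4 (0.08 log units; within the scatter). The two steps that start from a limit, an at least 1.5-fold lower number from compound 3 to compound 4 (0.20 log units; that floor lies within the scatter) and an at least 1.5-fold lower number from compound 2 to compound 4 (0.20 log units; that floor lies within the scatter), give only floors and cannot be sized, because they rest on: the limit of > 100000 nM in this assay, at which 2 of the 4 values shown sit.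

As far as these compounds go, it stays open whether ethynyl at this position truly differs from iodo, and whether methoxy truly differs from methylamino. The compounds shown also do not tell how a carboxylic acid, or an amine on a longer chain, would read at this position.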